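Ring nitrogen substituent series: methyl replaces 4-fluorophenyl

This account rests on a few compounds, and the source may have more. Where it says the series, first, only, none or still open, it means among the compounds named here.

Among the compounds with values here, compound 3 `Nc1ccccc1NC(=O)c1ccc(CSC(=S)N2CCN(c3ccc(F)cc3)CC2)cc1` gives 20.9% in a functional assay on A-375 cells (Homo sapiens) for antiproliferative activity, read by CCK-8 assay, with a stated time of 72 h, tested at 2 uM (on this read-out higher numbers stand for a stronger effect at the one concentration tested and lower numbers for a weaker effect), the lowest of the three numbers so far. Compound 1 `Nc1ccccc1NC(=O)c1ccc(CSC(=S)N2CCN(C3CCCCC3)CC2)cc1` gives 31.7% and compound 2 `COc1ccc(N2CCN(C(=S)SCc3ccc(C(=O)Nc4ccccc4N)cc3)CC2)cc1` gives 28.1%; the step of a number 10.8 percentage points lower from compound 1 to compound 3 (beyond the scatter) is the only one beyond the scatter, while a number 3.6 percentage points lower from compound 1 to compound 2 (within the scatter) and a number 7.2 percentage points lower from compound 2 to compound 3 (within the scatter) lie within it. Compound 4 `CN1CCN(C(=S)SCc2ccc(C(=O)Nc3ccccc3N)cc2)CC1` differs from compound 3 by methyl in place of 4-fluorophenyl on an amine nitrogen in a ring. Within the data shown here, no measured step exchanges this ring nitrogen substituent for methyl, so the three steps bear on it only loosely: the small group drops the aromatic ring of the leaving group, and the steps between the ring and non-ring substituents were modest or within the scatter. For compound 4 the expected step is a number 2.1 percentage points higher from compound 3 to compound 4 (within the scatter), roughly none beyond the scatter. Compound 4 is estimated at 23%, range 9% to 37%.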

Compound 4, a percentage reported as inhibition, at one concentration (the size of the read-out at that concentration, not a potency): 36.6%
Compound 4: the middle estimate sits 13.6 percentage points below what was measured; low and high end bracket the measured number.
By their numbers in this assay, from the lowest: compounds 3, 2, 1 and 4 (each within the scatter of the next, the first and the last beyond it).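

Against 4-fluorophenyl, methyl on the amine nitrogen in a ring gives a number 15.7 percentage points higher from compound 3 to compound 4 (beyond the scatter) while against 4-methoxyphenyl it gives a number 8.5 percentage points higher from compound 2 to compound 4 (within the scatter) and against cyclohexyl a number 4.9 percentage points higher from compound 1 to compound 4 (within the scatter) in this series. A single carbon here therefore keeps the read-out level with the two larger groups, so neither a six-membered ring nor an aromatic ring on this nitrogen is required, and only 4-fluorophenyl falls apart from methyl beyond the scatter. No evidence at hand accounts for that step.

Still open, from the compounds shown here alone, is whether a bare hydrogen, an ethyl group or a longer chain ending in a hydroxyl on this nitrogen would hold the number. With one concentration per compound, potency itself remains unread.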